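Chain extension in the series: cytotoxicity notes

The source may report more compounds than this note shows. Statements on the series, on what has been measured and on what is new or still open speak of the compounds shown alone.

Compound 1 `O=C1N(CCCCCCOc2ccc(Br)cc2)CCN1c1ccnc(Cl)c1`, compound 2 `O=C1N(CCCCCOc2ccc(Br)cc2)CCN1c1ccnc(Cl)c1` and compound 3 `O=C1N(CCCCCCOc2ccc(Br)cc2)CCN1c1ccncn1` were run in a functional assay on cells (Homo sapiens) for cytotoxicity; on this read-out higher numbers stand for lower toxicity in this test and lower numbers for higher toxicity in this test. For compound 1 the value > 25000 nM is a limit of the assay, not a number. Compound 2 likewise sits at a limit, > 25000 nM. Compound 3 also gives only a limit, > 25000 nM, so all three rest at the limit of > 25000 nM in this assay, at which 3 of the 3 values shown sit. The change (4-bromophenoxy)methyl in place of 4-bromophenoxy on a saturated chain carbon, five bonds along the chain from an amide-type nitrogen in a ring gives a step that the two limits leave unreadable from compound 2 to compound 1, the two limits leaving its size unreadable. The cores of compound 2 and compound 3 differ, but that difference is not broken down here; a step that the two limits leave unreadable from compound 1 to compound 3 is equally unreadable from two limits. Compound 4 `O=C1N(CCCCCCCOc2ccc(Br)cc2)CCN1c1ccncn1` carries the same kind of change, ((4-bromophenoxy)methyl in place of 4-bromophenoxy on a saturated chain carbon, six bonds along the chain from an amide-type nitrogen in a ring), the place now six bonds along the chain rather than five. With three limits and no readable step, compound 4 is expected to remain at the limit, its step of a number no higher from compound 3 to compound 4 (the limit leaves the size open) expected to be flat. The estimate for compound 4 is 25000 nM, spanning 20000 nM to 40000 nM.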

Compound 4, half-maximal cytotoxic concentration: > 25000 nM
Compound 4 gave a limit, no number; the forecaster's own chance of this, stated with the estimate: 85%; the middle value sits exactly at the limit.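

No step can be read from compound 3 to compound 4, as both values are limits: the limit of > 25000 nM in this assay, at which 4 of the 4 values shown sit.

The compounds shown leave open where any of them would give a number in this assay, and whether chain length changes it.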